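Moving the methoxy group from compound 2 to compound 3

The compounds below may be only part of what the source reports. "The series", "measured", "known", "first", "only" and "open" are said of these compounds alone.

Of the compounds shown here, two sharing one core have been measured so far. Compound 1 `Cc1ccc(C2C(C#N)=C(N)N(c3ccc(S(N)(=O)=O)cc3)C3=C2C(=O)CCC3)cc1` gives 30% in a functional assay on Ehrlich cells (Mus musculus) for antiproliferative activity, read by trypan blue exclusion, with a stated time of 2 h, tested at 25 ug/mL; on this read-out lower numbers stand for a weaker effect and higher numbers for a stronger effect at the one concentration tested. Compound 2 `COc1ccccc1C1C(C#N)=C(N)N(c2ccc(S(N)(=O)=O)cc2)C2=C1C(=O)CCC2` gives 0% in the same assay, the lowest of the two numbers; its nearest neighbour is compound 1, which stands higher, and the step of a number 30 percentage points lower from compound 1 to compound 2 (beyond the scatter) lies beyond the scatter.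

Compound 3 `COc1ccc(C2C(C#N)=C(N)N(c3ccc(S(N)(=O)=O)cc3)C3=C2C(=O)CCC3)cc1` has not been measured yet. It differs from compound 2 in one place: 4-methoxyphenyl in place of 2-methoxyphenyl on a saturated ring carbon Both compounds carry the same atoms, joined differently.

For the measured compounds named here, only one measured step exists, and it swaps a 4-methylphenyl group for a 2-methoxyphenyl group, so it changes both the kind of group and where it sits. It therefore bears only loosely on the present change, which keeps the methoxy group and shifts it. Compound 1, whose ring substituent also sits in the 4-position, gives a higher number than compound 2, which is the sole hint available. The step from compound 2 to compound 3 is expected to be a number 15 percentage points higher from compound 2 to compound 3 (beyond the scatter), modest and upward but not far beyond the scatter. Compound 3 is therefore estimated at 15%, with a range from 0% to 35%.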

Compound 3, a percentage reported as activity, at one concentration (the size of the read-out at that concentration, not a potency): 50%
The estimate for compound 3 lay 35 percentage points below the measured number; the measured number lies above the stated range.
By their numbers in this assay, from the lowest: compound 2; then compound 1; then compound 3.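

In this assay, moving the methoxy group alone changes the result greatly: the atoms stay the same, yet the 4-methoxyphenyl group gives a number 50 percentage points higher from compound 2 to compound 3 (beyond the scatter). Changing the group while keeping the 4-position also matters, since methoxy in place of methyl gives a number 20 percentage points higher from compound 1 to compound 3 (beyond the scatter), so the methoxy group cannot be blamed for the low number of compound 2 wherever it sits, and compound 3 is the strongest of the three at the one concentration tested. Nothing measured here explains why the position or the group has these effects.

The three compounds leave open whether the gap between the 2-methoxyphenyl and 4-methoxyphenyl groups is specific to methoxy, which a comparison of 2-methylphenyl with the 4-methylphenyl group of compound 1 could test. They also leave open how far the gain at the 4-position extends, for instance to a longer chain as in 4-ethoxyphenyl, to the 4-hydroxyphenyl group or to an amine as in 4-aminophenyl.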